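The compounds below may be only part of what the source reports. "The series", "measured", "known", "first", "only" and "open" are said of these compounds alone.

Measured so far:
compound 1 `CCCOC(=O)Nc1ccc([Se]C#N)cc1` — 21100 nM
compound 2 `CCCCOC(=O)Nc1ccc([Se]C#N)cc1` — 12400 nM

Two carbamates on the shared core. In a functional assay on PC-3 cells (Homo sapiens) for cytotoxicity, read by MTT assay, with a stated time of 72 h (a lower number here means a stronger inhibitor of growth, a higher number a weaker inhibitor of growth), compound 1 gives 21100 nM and compound 2 gives 12400 nM. Among the measured compounds shown here, of the two numbers compound 2 shows the smaller one, but the only step between them, a 1.7-fold lower number from compound 1 to compound 2 (0.23 log units; within the scatter), lies within the scatter, so the two compounds are not separated by these data.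

Compound 3 `CCOC(=O)Nc1ccc([Se]C#N)cc1` is not yet measured. It differs from compound 2 by hydrogen in place of ethyl on a saturated chain carbon, two bonds along the chain from an oxygen next to a carbonyl group. For the measured compounds named here, the one measured step that bears on this, a 1.7-fold lower number from compound 1 to compound 2 (0.23 log units; within the scatter), lengthened the same chain by one carbon and moved the number no further than the scatter allows. The change to compound 3 shortens the chain by two carbons, the reverse direction and a larger cut, so any shift is expected toward a higher number, and most likely one that stays inside or only just beyond the scatter.

The expected step is a 2.3-fold higher number from compound 2 to compound 3 (0.35 log units; beyond the scatter) for compound 3. Compound 3 is therefore estimated at 28000 nM, with a range of 11000 nM to 70000 nM.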

Compound 3, concentration for 50% growth inhibition: 9900 nM
Estimate against measurement, compound 3: 2.8-fold (0.45 log units) above; the whole stated range lies above it.
By their numbers in this assay, from the lowest: compounds 3, 2 and 1 (each within the scatter of the next, the first and the last beyond it).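

In this assay, hydrogen in place of ethyl on the saturated chain carbon, two bonds along the chain from an oxygen next to a carbonyl group, gives a 1.3-fold lower number from compound 2 to compound 3 (0.10 log units; within the scatter), so this larger cut, butoxy to ethoxy, leaves the number within the scatter and the chain is not needed at full length for growth inhibition at this level. Among the compounds shown here, the same place with hydrogen in place of methyl gives a 2.1-fold lower number from compound 1 to compound 3 (0.33 log units; beyond the scatter), the first step to clear the scatter, though only modestly, and it runs toward a lower number on shortening. Taken with the earlier step, this leaves no steady trend with chain length: only the two ends of the set are separated, and compound 2 cannot be told apart from either of them; nothing at hand accounts for this flat response.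

Going by these compounds, whether a chain longer than butyl, a branched chain, or an amine or carboxylic acid at the chain end would move the number clearly beyond the scatter remains open. Also open, on these data alone, is whether methoxy in place of ethoxy would continue the shift seen with compound 3 or reverse it.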